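Replacing the ring on the chain: what to expect of compound 3

The compounds below may be only part of what the source reports. "The series", "measured", "known", "first", "only" and "open" are said of these compounds alone.

Compound 1 `O=S(=O)(/C=C/c1ccc(Cl)c(Cl)c1)Cc1ccc(Nc2ncnc3ccccc23)cc1` gives 41000 nM
Compound 2 `O=S(=O)(/C=C/c1ccc(F)cc1Cl)Cc1ccc(Nc2ncnc3ccccc23)cc1` gives 100000 nM

In a functional assay on SW-620 cells (Homo sapiens) (a lower number here means a stronger inhibitor of growth, a higher number a weaker inhibitor of growth), compound 2 stands highest of the two measured compounds at 100000 nM, which makes it the weaker growth inhibitor of the pair. Compound 3 `O=S(=O)(/C=C/c1ccc(O)cc1)Cc1ccc(Nc2ncnc3ccccc23)cc1` keeps the rest of the structure and changes one group, on a double-bonded chain carbon bound to a double-bonded chain carbon: 4-hydroxyphenyl in place of 2-chloro-4-fluorophenyl on a double-bonded chain carbon bound to a double-bonded chain carbon. Among the measured compounds shown here, only one measured step bears on this, a change at that same place: a 2.4-fold higher number from compound 1 to compound 2 (0.39 log units; beyond the scatter). For the measured compounds named here, it was modest, and no measured compound carries a 4-hydroxyphenyl group, so the guidance is thin. Going by the values given here, since compound 2 gives 100000 nM, the higher of only two numbers, a small move down seems more likely than a move up. The estimated change, not clearly beyond the scatter, is a 1.7-fold lower number from compound 2 to compound 3 (0.22 log units; within the scatter). For compound 3 the expected value is 60000 nM, with an estimated range of 20000 nM to 150000 nM.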

Compound 3, concentration for 50% growth inhibition: 100000 nM
Estimate against measurement, compound 3: 1.7-fold (0.22 log units) below; low and high end bracket the measured number.
By their numbers in this assay, from the lowest: compound 1; then compounds 2 and 3 (each within the scatter of the next).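

In this assay, the change from 2-chloro-4-fluorophenyl to 4-hydroxyphenyl leaves the result the same (as the step reads, no change at the digits printed from compound 2 to compound 3 (within the scatter)) even though the two groups differ in their atoms and the entering group has a hydrogen-bond donor and acceptor. The second comparison (as the step reads, a 2.4-fold higher number from compound 1 to compound 3 (0.39 log units; beyond the scatter)) is modest but beyond the scatter, so compound 1, with its 3,4-dichlorophenyl group, is the strongest growth inhibitor of the three, and two quite different rings do not match it. Nothing available here explains these results.

Among the compounds shown here, whether 3,4-dichlorophenyl is an unusually favourable group at this place remains open, since only three rings can be compared. An amine, a carboxylic acid or a methoxy group on the ring could move the number either way.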